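The source may hold more compounds than are shown below. What is called first, only, known or untested is meant among the compounds shown, and "the series" means these compounds.

Compound 2 `COc1ccc(C(=O)Nc2cccc(/C=C/C(=O)c3nc4ccccc4[nH]3)c2)cc1` and compound 1 `O=C(Nc1cccc(/C=C/C(=O)c2nc3ccccc3[nH]2)c1)c1cccc(C(F)(F)F)c1` share one core and differ only in the aryl group attached to the amide carbonyl. In a functional assay on 143B cells (Homo sapiens) for antiproliferative activity, read by MTT assay, with a stated time of 48 h (a higher number here means a weaker inhibitor, a lower number a stronger inhibitor), compound 1 gives 9570 nM, and in this assay compound 2 gives 6330 nM. The step of a 1.5-fold lower number from compound 1 to compound 2 (0.18 log units; within the scatter) does not separate the two compounds, so compound 2 stands alongside compound 1 within the usual scatter rather than apart from it.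

Compound 3 `O=C(Nc1cccc(/C=C/C(=O)c2nc3ccccc3[nH]2)c1)c1cc(Cl)cc(Cl)c1` carries the change (3,5-dichlorophenyl in place of 4-methoxyphenyl on a carbonyl carbon). Among the measured compounds shown here, only one measured step bears on this kind of change, the exchange of the aryl group on the amide carbonyl from compound 1 to compound 2, and that step, a 1.5-fold lower number from compound 1 to compound 2 (0.18 log units; within the scatter), stayed within the scatter. With no other evidence, no step beyond the scatter is expected from compound 2 to compound 3 in this assay, in either direction; the estimated step is a 1.1-fold higher number from compound 2 to compound 3 (0.04 log units; within the scatter). Compound 3 is therefore expected to give about 7000 nM in this assay, with a plausible range from 2500 nM to 20000 nM.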

Compound 3, half-maximal inhibitory concentration: 3660 nM
For compound 3 the middle estimate is 1.9-fold (0.28 log units) above the measured one; the range from low to high includes it.
By their numbers in this assay, from the lowest: compounds 3, 2 and 1 (each within the scatter of the next, the first and the last beyond it).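

In this assay the aryl group on the amide carbonyl gives its first step beyond the scatter: 3,5-dichlorophenyl in place of 3-(trifluoromethyl)phenyl yields a 2.6-fold lower number from compound 1 to compound 3 (0.42 log units; beyond the scatter), so the number at this position can respond to the exchange of one substituted phenyl group for another, though only modestly. The exchange of 4-methoxyphenyl for 3,5-dichlorophenyl yields a 1.7-fold lower number from compound 2 to compound 3 (0.24 log units; within the scatter), which leaves that pair together, and since compound 2 also lies within the scatter of compound 1, the three aryl groups do not fall into three separate levels. No measurement is available here that would account for the gap between compound 1 and compound 3.

From the compounds shown here alone, all three groups at this position are substituted phenyl rings, so it remains open how the number would respond to a phenyl ring carrying an amine or a carboxylic acid, or to a saturated ring such as cyclohexyl. Going by these compounds, it also remains open whether a single chlorine, as in 3-chlorophenyl, would stand with compound 3 or with compound 1.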